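Swapping Fluoro for a Larger Group on Compound 3

This account rests on a few compounds, and the source may have more. Where it says the series, first, only, none or still open, it means among the compounds named here.

Three measured compounds share one core and differ in the aromatic group on the amide nitrogen. In an ADME assay on BaF3 cells (Mus musculus) for antiproliferative activity, read by CCK-8 assay, with a stated time of 72 h (a lower number here means a stronger inhibitor of growth, a higher number a weaker inhibitor of growth), compound 1 `COc1cccc(NC(=O)CCSc2ccc3c(/C=C/c4ccccn4)n[nH]c3c2)c1` gives 3840 nM as its read-out. Compound 2 `CN(C)c1cccc(NC(=O)CCSc2ccc3c(/C=C/c4ccccn4)n[nH]c3c2)c1` gives > 10000 nM and this is a limit of the assay, not a number. Compound 3 `O=C(CCSc1ccc2c(/C=C/c3ccccn3)n[nH]c2c1)Nc1ccc(F)c(C(F)(F)F)c1` gives 610 nM and so holds the lowest number of the set.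

Compound 4 `O=C(CCSc1ccc2c(/C=C/c3ccccn3)n[nH]c2c1)Nc1ccc(CN2CCCC2)c(C(F)(F)F)c1` differs from compound 3 in one place: (pyrrolidin-1-yl)methyl in place of fluoro on an aromatic carbon. The incoming group sits ortho to a trifluoromethyl group, which stays.

Among the measured compounds shown here, no measured step makes this exact swap, so the evidence is indirect. Bringing in the whole 4-fluoro-3-(trifluoromethyl)phenyl group gave a 6.3-fold lower number from compound 1 to compound 3 (0.80 log units; beyond the scatter) and also an at least 16-fold lower number from compound 2 to compound 3 (1.21 log units; beyond the scatter). Those steps cannot separate the fluoro from the trifluoromethyl, and compound 4 keeps only the trifluoromethyl. For the measured compounds named here, the one swap that introduced an amine, dimethylamino in place of methoxy, gave an at least 2.6-fold higher number from compound 1 to compound 2 (0.41 log units; beyond the scatter) and counsels caution, although that group is a different one at a different place. These hints do not settle a direction, so the expected change is small and uncertain: a 1.2-fold lower number from compound 3 to compound 4 (0.09 log units; within the scatter), which is none beyond the scatter. For compound 4 the estimate is 500 nM, with an expected range from 100 nM to 2500 nM in this assay.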

Compound 4, concentration for 50% growth inhibition: 4000 nM
The estimate for compound 4 lay 8.0-fold (0.90 log units) below the measured number, outside the stated range (above it).
By their numbers in this assay, from the lowest: compound 3; then compounds 1 and 4 (each within the scatter of the next). At a limit, above all of these: compound 2.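

Among the compounds shown here, compound 4 gives the first direct reading of this position, the aromatic carbon ortho to a trifluoromethyl group. In this assay, for the compounds shown here, (pyrrolidin-1-yl)methyl in place of fluoro gives a 6.6-fold higher number from compound 3 to compound 4 (0.82 log units; beyond the scatter), so keeping the trifluoromethyl group is not enough to hold the low number of compound 3, something the earlier steps could not show because they brought in fluoro and trifluoromethyl together. The swap puts a ring, a nitrogen and more heavy atoms at this place in a single change, and nothing measured here gives a cause for the step.

The compounds shown leave open which part of the incoming group matters, since an all-carbon group such as ethyl or cyclopentylmethyl at this place would separate the nitrogen from the added carbon atoms. An open-chain amine such as dimethylaminomethyl, or a hydroxyl group, at the same place would also show whether the pyrrolidine ring itself is tied to the higher number or whether any replacement of fluoro here brings a similar rise.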